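The source may report more compounds than this note shows. Statements on the series, on what has been measured and on what is new or still open speak of the compounds shown alone.

Measured in a functional assay on RAW264.7 cells (Mus musculus) for inhibition, with a stated time of 30 min; on this read-out higher numbers stand for weaker inhibition and lower numbers for stronger inhibition:
compound 1 `C=C1C(=O)OC[C@@H]1CCOC(=O)Nc1ccc(C(C)C)cc1` gives 1580 nM
compound 2 `C=C1C(=O)OC[C@H]1CCOC(=O)Nc1cc(C)cc(C)c1` gives 480 nM

Compound 1 has the higher number of the two, meaning weaker inhibition, and its gap to compound 2 lies beyond the scatter. Compound 3 `C=C1C(=O)OC[C@@H]1CCOC(=O)Nc1ccc(CC)cc1` changes compound 1 in one place, with hydrogen in place of methyl on a saturated chain carbon bound to an aromatic carbon and a saturated chain carbon, turning isopropyl into ethyl: hydrogen in place of methyl on a saturated chain carbon bound to an aromatic carbon and a saturated chain carbon is the counted difference. Among the compounds with values here, no measured pair shows this change, so the expectation is loose: no step beyond the scatter in this assay is expected. The expected step is a 1.2-fold lower number from compound 1 to compound 3 (0.08 log units; within the scatter) as an estimate. Compound 3 is estimated at 1300 nM with an expected range from 550 nM to 3000 nM in this measurement.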

Compound 3, half-maximal inhibitory concentration: 1260 nM
Compound 3: the middle estimate sits 1.0-fold (0.01 log units) above what was measured, within the range that was stated.
By their numbers in this assay, from the lowest: compound 2; then compounds 3 and 1 (each within the scatter of the next).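

In this assay the change from isopropyl to ethyl gives a 1.3-fold lower number from compound 1 to compound 3 (0.10 log units; within the scatter) and forms the first pair shown that differs in one place. Hydrogen can therefore take the place of methyl on this saturated chain carbon, bound to an aromatic carbon and a saturated chain carbon, with no step beyond the scatter. The compounds shown leave open whether a longer chain such as butyl, or an amine, in place of the ethyl would give a step beyond the scatter. No measurement at hand offers an explanation for this result.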